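The source may report more compounds than this note shows. Statements on the series, on what has been measured and on what is new or still open speak of the compounds shown alone.

Compound 1 `CCNC(=O)Nc1nc2cc(-c3cnc(N4CCC(C(=O)O)CC4)nc3)cc(-c3ccccn3)c2s1` and compound 2 `CCNC(=O)Nc1nc2cc(-c3cnc(N4CCC(CC)(C(=O)O)CC4)nc3)cc(-c3ccccn3)c2s1` share one core and differ only on a saturated ring carbon. In a physicochemical assay for solubility, read by turbidimetry, in phosphate buffer, with a stated time of 24 h, at pH 7.4 (a higher number here means a more soluble compound, a lower number a less soluble compound), compound 1 gives > 800 ug/mL, which is a limit of the assay and not a number. In this assay compound 2 likewise gives > 800 ug/mL, again a limit. The step that the two limits leave unreadable from compound 1 to compound 2 is thus unreadable, since both values sit at the limit of > 800 ug/mL in this assay, at which 2 of the 2 values shown sit. Compound 3 `CCNC(=O)Nc1nc2cc(-c3cnc(N4CCC(C(=O)O)(C(F)(F)F)CC4)nc3)cc(-c3ccccn3)c2s1` differs from compound 2 by trifluoromethyl in place of ethyl on a saturated ring carbon. Among the measured compounds shown here, with the only measured step unreadable, the expected step of a number no higher from compound 2 to compound 3 (the limit leaves the size open) is none beyond the scatter. Compound 3 is therefore estimated at 800 ug/mL, within 300 ug/mL to 1500 ug/mL, most likely reported once more as a limit.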

Compound 3, solubility: > 800 ug/mL
Compound 3 ended at the assay's limit (the forecaster's own chance of this, stated with the estimate: 70%); the middle value sits exactly at the limit.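

No step can be read among compound 1, compound 2 and compound 3 in this assay, as all three values are one limit: the limit of > 800 ug/mL in this assay, at which 3 of the 3 values shown sit. On these data alone, whether these compounds differ at all in solubility stays open.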